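From Ethoxy to Tert-Butyl on a Shared Core

A few compounds are considered here, and "the series" means these few. Any claim that something is new, unique, unknown or untested is made for them only; others in the source may bear on it.

Among the compounds with values here, in a functional assay on MCF7 cells (Homo sapiens) for cytotoxicity (on this read-out higher numbers stand for an effect only at larger amounts of compound and lower numbers for an effect already at smaller amounts), compound 3 `CCOc1ccc(/C=C/c2cc(OC)c(OC)c(OC)c2)cc1` gives 7.5 uM, the second highest of the three numbers measured so far. Compound 1 `COc1cc(/C=C/c2ccc(C(C)C)cc2)cc(OC)c1OC` stands higher at 18.4 uM, while compound 2 `COc1cc(/C=C\c2ccc(C(C)(C)C)cc2)cc(OC)c1OC` stands lowest at 1.57 uM. The next structure, compound 4 `COc1cc(/C=C/c2ccc(C(C)(C)C)cc2)cc(OC)c1OC`, carries tert-butyl in place of ethoxy on an aromatic carbon, para to a large group (tert-butyl in place of ethoxy on an aromatic carbon).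

Within the data shown here, only one measured step bears directly on this change: a 2.5-fold lower number from compound 1 to compound 3 (0.39 log units; beyond the scatter). That modest step put ethoxy in place of isopropyl, so it ran from a carbon-only group to ethoxy. The new change runs the other way, leaving ethoxy for tert-butyl, another carbon-only group. If tert-butyl behaves much like isopropyl, the number should rise by a similar modest amount, but no measurement has yet tested that assumption. Among the measured compounds shown here, compound 2 is not linked to compound 3 by a single change, so it offers no measured step here, and the range is kept wide.

The expected change is a 2.0-fold higher number from compound 3 to compound 4 (0.30 log units; within the scatter), towards a higher number in this assay. Compound 4 is estimated at 15 uM, with an expected range from 5 uM to 40 uM.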

Compound 4, concentration for half-maximal effect: > 25 uM
Compound 4: only a limit was reported (the forecaster's own chance of this, stated with the estimate: 3%); middle value at least 1.6-fold (0.22 log units) away from the limit.
By their numbers in this assay, from the lowest: compound 2; then compound 3; then compound 1. At a limit, above all of these: compound 4.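

In this assay compound 4 gives only a limit, > 25 uM, rather than a number: the limit of > 25 uM in this assay, at which 1 of the 4 values shown sits. Even so, a direction can be read at this place on the aromatic ring, para to a large group, with an at least 3.3-fold higher number from compound 3 to compound 4 (0.52 log units; beyond the scatter), while an at least 1.3-fold higher number from compound 1 to compound 4 (0.13 log units; that floor lies within the scatter), so that limit does not separate tert-butyl from isopropyl here. The largest gap comes with tert-butyl kept in place, an at least 15-fold higher number from compound 2 to compound 4 (1.20 log units; beyond the scatter), which shows that tert-butyl alone does not set the number and ties this gap to the double bond, drawn Z in compound 2 and E in compound 4: the fact that compounds 2 and 4 differ only in the configuration as drawn.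

The limit leaves open how far compound 4 really lies from the other compounds, and with only one Z and E pair shown, it remains open whether ethoxy or isopropyl would show a similar gap. Also open, from the compounds shown here alone, is how an amine or a carboxylic acid at this same place would read in this assay, on either form of the double bond.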